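This account rests on a few compounds, and the source may have more. Where it says the series, first, only, none or still open, it means among the compounds named here.

Within the data shown here, compound 1 `Cc1cc(C)c(CN2CCc3c(F)cc(O[C@@H]4CCOC4)c(Cl)c3C2=O)c(=O)[nH]1` gives 56 nM in an assay on Sf9 cells for inhibition of histone-lysine N-methyltransferase EZH2 (Homo sapiens), read by scintillation counting, with a stated time of 60 min, in the presence of a further agent that is not named here (on this read-out lower numbers stand for stronger inhibition and higher numbers for weaker inhibition), the lowest of the three numbers measured so far. Compound 2 `COc1ccc2c(c1Cl)C(=O)N(Cc1c(C)cc(C)[nH]c1=O)CCC2` gives 150 nM in this assay, a gap from compound 1 that lies beyond the usual scatter, and compound 3 `COc1cccc(C(=O)NCc2c(C)cc(C)[nH]c2=O)c1O` gives 44000 nM in this assay, which is far weaker than either. Compound 4 `Cc1cc(C)c(CN2CCc3ccc(O[C@@H]4CCOC4)c(Cl)c3C2=O)c(=O)[nH]1` differs from compound 1 in one place: hydrogen in place of fluoro on an aromatic carbon. Among the measured compounds shown here, no measured pair shows what this particular change does here, so the forecast rests on the size of the change alone. A small loss is expected, with the step of a 2.0-fold higher number from compound 1 to compound 4 (0.29 log units; within the scatter) lying at or just beyond the scatter. Compound 4 is therefore estimated at 110 nM in this assay, with a range from 45 nM to 270 nM.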

Compound 4, half-maximal inhibitory concentration in the histone-lysine N-methyltransferase EZH2 assay: 28 nM
Estimate against measurement, compound 4: 3.9-fold (0.59 log units) above, and the stated range ends above it.
By their numbers in the histone-lysine N-methyltransferase EZH2 assay, from the lowest: compounds 4 and 1 (each within the scatter of the next); then compound 2; then compound 3.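

In the histone-lysine N-methyltransferase EZH2 assay, the swap gives a 2.0-fold lower number from compound 1 to compound 4 (0.30 log units; within the scatter), so on this core inhibition does not depend measurably on fluoro at this aromatic carbon. The swap does register in a physicochemical assay for lipophilicity, at pH 7.4 (a lower number here means a more polar compound, a higher number a more lipophilic compound), where compound 1 gives 2.1 and compound 4 gives 1.5, a gap beyond the scatter. This single change therefore shifts the distribution coefficient without a readable shift in inhibition.

Going by these compounds, whether a methyl, methoxy or nitrile group on the same carbon would also leave inhibition unchanged remains open. A single pair also cannot show whether this swap behaves the same way on other cores.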